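Adding Chloro to the Phenyl Group of Compound 2

The source may hold more compounds than are shown below. What is called first, only, known or untested is meant among the compounds shown, and "the series" means these compounds.

In a functional assay on NCI-H661 cells (Homo sapiens) for antiproliferative activity, read by MTT assay, with a stated time of 72 h (on this read-out higher numbers stand for weaker inhibition and lower numbers for stronger inhibition), compound 2 `Nc1ccccc1NC(=O)CCCCCCc1nc(-c2ccccc2)no1` gives 960 nM and stands lowest of the two measured compounds. Compound 1 `O=C(CCCCCCc1nc(-c2ccccc2Cl)no1)NO` gives 10300 nM as a higher number, beyond the scatter. Compound 3 `Nc1ccccc1NC(=O)CCCCCCc1nc(-c2ccc(Cl)cc2)no1` departs from compound 2 by chloro in place of hydrogen on an aromatic carbon with chloro in place of hydrogen on an aromatic carbon, para to a large group. Among the measured compounds shown here, no measured pair shows this change alone. The expected step of a 1.2-fold lower number from compound 2 to compound 3 (0.08 log units; within the scatter) in this assay is none beyond the scatter. Compound 3 is estimated at 800 nM with an expected range from 300 nM to 2200 nM in this read-out.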

Compound 3, half-maximal inhibitory concentration: 11200 nM
Compound 3: the middle estimate sits 14-fold (1.15 log units) below what was measured; measured number outside the range, above it.
By their numbers in this assay, from the lowest: compound 2; then compounds 1 and 3 (each within the scatter of the next).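

Chloro in place of hydrogen on an aromatic carbon, para to a large group, gives a 12-fold higher number from compound 2 to compound 3 (1.07 log units; beyond the scatter) in this assay, so this position does not tolerate the phenyl to 4-chlorophenyl change without a large loss. The earlier compounds shown here could not show this, since compound 1 and compound 2 differ in more than one place. Nothing available accounts for the loss.

The compounds shown leave open whether fluoro, methyl or methoxy in the same place would bring a similar step. They also leave open whether an amine there would do so.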